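This account rests on a few compounds, and the source may have more. Where it says the series, first, only, none or still open, it means among the compounds named here.

Measured so far:
compound 1, `NCc1nnc(Cc2ccccc2)s1`, 110 mg/kg
compound 2, `CNCc1nnc(-c2ccccc2)s1`, > 200 mg/kg
compound 3, `CC(N)c1nnc(-c2ccccc2-c2ccccc2)s1`, 21 mg/kg

The read-out is a functional assay on the whole organism with Mus musculus as the target; a lower number here means that less compound is needed, a higher number that more compound is needed for the effect. Compound 2 gives only a limit here, (the limit of > 200 mg/kg in this assay, at which 1 of the 3 values shown sits), so its position on the measured numbers is not fixed. Compound 4, `CCCCCCOc1ccccc1-c1nnc(CNC)s1`, differs from compound 2 by hexyloxy in place of hydrogen on an aromatic carbon. Among the measured compounds shown here, no step between two measured compounds that differ in one place has been recorded, so the size of this change can only be guessed. Compound 3 gives 21 mg/kg in this assay, and compound 1 gives 110 mg/kg. The change is expected to bring compound 4 into the measurable range, with a step of an at least 2.8-fold lower number from compound 2 to compound 4 (0.45 log units; beyond the scatter). Compound 4 is estimated at 70 mg/kg, between 20 mg/kg and 200 mg/kg.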

Compound 4, dose for half-maximal effect: 44 mg/kg
For compound 4 the middle estimate is 1.6-fold (0.20 log units) above the measured one; the measured number falls inside the stated range.
By their numbers in this assay, from the lowest: compound 3; then compound 4; then compound 1. At a limit, above all of these: compound 2.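

Placed on an aromatic carbon of the six-membered aromatic ring, ortho to a group of 8 heavy atoms, hexyloxy gives the only single-place step available in this assay, and it is an at least 4.5-fold lower number from compound 2 to compound 4 (0.65 log units; beyond the scatter). This shows that the position tolerates the chain and that adding it brings the compound into the measurable range. Compound 2 gives only a limit, so the full size of the step stays unknown: the limit of > 200 mg/kg in this assay, at which 1 of the 4 values shown sits.

The compounds shown leave open whether a shorter chain such as methoxy, or a longer chain, would give a similar step at this place. They also leave open whether an amine there would do the same.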